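Replacing the cyanophenyl sulfone with a difluorophenyl sulfone

This account rests on a few compounds, and the source may have more. Where it says the series, first, only, none or still open, it means among the compounds named here.

Compound 2 `N#Cc1cccc(S(=O)(=O)c2cnc3c(F)cccc3c2-c2cccc(F)c2)c1`: 0.34 mL/min
Compound 1 `COc1cccc(-c2c(S(=O)(=O)c3cc(F)cc(F)c3)cnc3c(F)cccc23)c1`: 2.76 mL/min

In an ADME assay on microsomes from liver (Homo sapiens) for metabolic stability, tested at 2.5 uM (on this read-out lower numbers stand for slow clearance and higher numbers for fast clearance), compound 2 gives the lowest of the two numbers, and compound 1 gives the higher one, with the gap between them lying beyond the scatter. Compound 3 `O=S(=O)(c1cc(F)cc(F)c1)c1cnc2c(F)cccc2c1-c1cccc(F)c1` carries the change 3,5-difluorophenyl in place of 3-cyanophenyl on a sulfonyl sulfur and shares its sulfonyl group with compound 1. For compound 3 the expectation is an upward step a 4.4-fold higher number from compound 2 to compound 3 (0.64 log units; beyond the scatter) in this assay, since compound 1 gives 2.76 mL/min. Compound 3 is therefore estimated at 1.5 mL/min, within 0.6 mL/min to 3.5 mL/min.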

Compound 3, intrinsic clearance in a liver preparation (reported as CLH), per the amount of preparation that the assay uses: 1.18 mL/min
The estimate for compound 3 lay 1.3-fold (0.10 log units) above the measured number; low and high end bracket the measured number.
By their numbers in this assay, from the lowest: compound 2; then compound 3; then compound 1.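

In this assay, 3,5-difluorophenyl in place of 3-cyanophenyl on a sulfonyl sulfur gives a 3.5-fold higher number from compound 2 to compound 3 (0.54 log units; beyond the scatter), so this single change raises the number on its own. Fluoro in place of methoxy on an aromatic carbon gives a 2.3-fold lower number from compound 1 to compound 3 (0.37 log units; beyond the scatter), so the other place that separates compound 1 from compound 2 also moves the number. Nothing at hand gives a reason for either step.

The compounds shown leave open whether the two changes add up when 3-cyanophenyl on the sulfonyl sulfur is paired with methoxy on the aromatic carbon. They also leave open how an aminophenyl group would read on that sulfur.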